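Anilino in place of oxazolyl methylamino on the shared core

A few compounds are considered here, and "the series" means these few. Any claim that something is new, unique, unknown or untested is made for them only; others in the source may bear on it.

Measured so far in an ADME assay on microsomes from liver (Homo sapiens) for metabolic stability, read by LC-MS, using NADPH, with stated times of 5 min and 30 min, tested at 1 uM; on this read-out higher numbers stand for fast clearance and lower numbers for slow clearance:
compound 1 `O=C1c2ccccc2CN1c1cnc(NCc2c(F)ccc3c2CCO3)n2cnnc12` gives 13 mL.min-1.g-1
compound 2 `O=C(Nc1cnc(NCc2c(F)ccc3c2CCO3)n2cnnc12)c1cccnc1` gives only a limit, < 3 mL.min-1.g-1
compound 3 `CN(c1ncco1)c1cnc(NCc2c(F)ccc3c2CCO3)n2cnnc12` gives 11 mL.min-1.g-1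

Compound 3 and compound 1 sit within the scatter of each other in this assay, as the step of a 1.2-fold lower number from compound 1 to compound 3 (0.07 log units; within the scatter) shows. Compound 2 sits at a limit, (the limit of < 3 mL.min-1.g-1 in this assay, at which 1 of the 3 values shown sits), so its value is not a number. The step of an at least 3.6-fold higher number from compound 2 to compound 3 (0.56 log units; beyond the scatter) is beyond the scatter.

Compound 4 `Fc1ccc2c(c1CNc1ncc(Nc3ccccc3)c3nncn13)CCO2` is not yet measured. The change from compound 3 is anilino in place of methyl(1,3-oxazol-2-yl)amino on an aromatic carbon. Among the measured compounds shown here, two measured steps bear on it: the exchange of the group at this position between compound 1 and compound 3 gave a step within the scatter, while the exchange between compound 2 and compound 3 gave a modest step. For the measured compounds named here, no measured step covers an anilino group. The expectation for compound 4 is therefore a step of about a 1.3-fold higher number from compound 3 to compound 4 (0.10 log units; within the scatter) in this assay, that is, no movement beyond the scatter. Compound 4 is estimated at 14 mL.min-1.g-1, with a range from 6 mL.min-1.g-1 to 35 mL.min-1.g-1.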

Compound 4, intrinsic clearance in microsomes: 20 mL.min-1.g-1
Compound 4: middle estimate off by 1.4-fold (0.15 log units), on the low side; low and high end bracket the measured number.
By their numbers in this assay, from the lowest: compounds 3, 1 and 4 (each within the scatter of the next). At a limit, below all of these: compound 2.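

In this assay, anilino in place of methyl(1,3-oxazol-2-yl)amino gives a 1.8-fold higher number from compound 3 to compound 4 (0.26 log units; within the scatter), and anilino in place of the group of compound 1 gives a 1.5-fold higher number from compound 1 to compound 4 (0.19 log units; within the scatter), so three different groups on this aromatic carbon now sit within the scatter of each other. Compound 4 keeps a hydrogen on the nitrogen, as compound 2 does, yet phenyl in place of (pyridin-3-yl)carbonyl on that nitrogen gives an at least 6.6-fold higher number from compound 2 to compound 4 (0.82 log units; beyond the scatter), so that hydrogen alone does not go with the separation seen for compound 2. Compound 2 stands at a limit, not at a number: the limit of < 3 mL.min-1.g-1 in this assay, at which 1 of the 4 values shown sits.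

Open, from the compounds shown here alone, is whether the carbonyl or the pyridine ring of compound 2 goes with its separation from the others; benzoylamino or pyridin-3-ylamino on the same aromatic carbon would tell the two apart. Also open, going by these compounds, is how a saturated amine such as morpholine would read at this position.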